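Phenyl in place of cyclohexyl on the amide of compound 3

The source may report more compounds than this note shows. Statements on the series, on what has been measured and on what is new or still open speak of the compounds shown alone.

Compound 1 `O=C(Nc1cc2nc(-c3ccco3)[nH]c2cc1N1CCCCC1)c1cccc2ccccc12`: in an ADME assay on Vero cells (Chlorocebus sabaeus) for cytotoxicity, with a stated time of 3 days (a higher number here means a weaker inhibitor, a lower number a stronger inhibitor), compound 1 reaches only the limit of the assay, > 200 ug/mL.
Compound 2 `CN(C)CCN(C)c1cc2[nH]c(C3CCCCC3)nc2cc1NS(=O)(=O)c1ccccc1`: in this assay compound 2 likewise gives only a limit, > 200 ug/mL.
Compound 3 `CCOC(=O)Nc1cc(NC(=O)C2CCCCC2)c2[nH]c(-c3ccc(C(=O)OC)cc3)nc2c1`: in this assay compound 3 also gives only a limit, > 200 ug/mL.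

Among the measured compounds shown here, compound 3 thus stands where every measured compound stands, at the limit of > 200 ug/mL in this assay, at which 3 of the 3 values shown sit; no number is known for any of them, and no step between measured compounds can be read. Compound 4 `CCOC(=O)Nc1cc(NC(=O)c2ccccc2)c2[nH]c(-c3ccc(C(=O)OC)cc3)nc2c1` differs from compound 3 by phenyl in place of cyclohexyl on a carbonyl carbon. For the measured compounds named here, with no measured step to draw on, the step of a number no higher from compound 3 to compound 4 (the limit leaves the size open) in this assay is expected to be none beyond the scatter. Compound 4 is therefore expected to give 200 ug/mL in this assay, within 100 ug/mL to 400 ug/mL, most likely again reported only as a limit.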

Compound 4, half-maximal inhibitory concentration: 650 ug/mL
Compound 4: middle estimate off by 3.3-fold (0.51 log units), on the low side, outside the stated range (above it).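

In this assay, among the compounds shown here, compound 3 is known only as a limit, and no step from it to compound 4 can be read. The compounds shown leave open how much phenyl in place of cyclohexyl on a carbonyl carbon changes the value.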